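The source may report more compounds than this note shows. Statements on the series, on what has been measured and on what is new or still open speak of the compounds shown alone.

Within the data shown here, in a functional assay on DU-145 cells (Homo sapiens) for cytotoxicity, read by sulforhodamine B assay, with a stated time of 3 days (a lower number here means that less compound is needed, a higher number that more compound is needed for the effect), compound 1 (`COc1c(-c2occ(C)c2COC(C)=O)ccc2c1CCCC2(C)C`) gives 16.7 uM, the lower of the two numbers so far, while compound 2 (`Cc1coc(-c2ccc3c(c2O)CCC3)c1C(=O)O`) gives 38.4 uM, a gap beyond the usual scatter. Compound 3 (`COc1c(-c2occ(C)c2CO)ccc2c1CCCC2(C)C`) has not yet been measured. It carries hydrogen in place of acetyl on an oxygen on a saturated carbon, taking acetoxymethyl to hydroxymethyl: hydrogen in place of acetyl on an oxygen on a saturated carbon. Among the measured compounds shown here, no measured pair shows a single change, so the data offer no direct guide. In this assay, no step beyond the scatter is expected, only a slight lean toward a higher number. The expected step is a 1.3-fold higher number from compound 1 to compound 3 (0.12 log units; within the scatter). Compound 3 is estimated at 22 uM, with an expected range of 9 uM to 55 uM.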

Compound 3, concentration for half-maximal effect: 21.7 uM
Beside the measured number, compound 3's estimate is 1.0-fold (0.01 log units) above it; measured number inside the range.
By their numbers in this assay, from the lowest: compounds 1, 3 and 2 (each within the scatter of the next, the first and the last beyond it).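

Hydrogen in place of acetyl on an oxygen on a saturated carbon gives, in this assay, a 1.3-fold higher number from compound 1 to compound 3 (0.11 log units; within the scatter), the first single change that can be read in this series. At this position the acetyl group is therefore not required for a number in the range of compound 1. Nothing at hand bears on why the two compounds read alike.

From the compounds shown here alone, what remains open is whether an amine or a longer ester such as butyrate in place of the hydroxy group would move the number beyond the scatter.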